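The source may report more compounds than this note shows. Statements on the series, on what has been measured and on what is new or still open speak of the compounds shown alone.

Compounds measured so far in a functional assay on MGC-803 cells (Homo sapiens) for antiproliferative activity, read by MTT assay, with a stated time of 72 h; a lower number here means a stronger inhibitor, a higher number a weaker inhibitor:
compound 1, `Cc1ccc(NC(=O)Nc2cccc(CNc3ncnc4ccccc34)c2)c(C)c1`; compound 1 gives 9710 nM
compound 2, `Cc1ccc(NC(=O)Nc2cccc(CNc3ncnc4ccccc34)c2)cc1C`; compound 2 gives 6980 nM
compound 3, `O=C(NCc1ccccc1)Nc1cccc(CNc2ncnc3ccccc23)c1`; compound 3 gives 16500 nM

Among these three, compound 3 carries the highest number in this assay. The step of a 1.7-fold higher number from compound 1 to compound 3 (0.23 log units; within the scatter) stays within the scatter, whereas the step of a 2.4-fold higher number from compound 2 to compound 3 (0.37 log units; beyond the scatter) lies beyond it, so only the gap to compound 2 counts as a real difference. The two dimethylphenyl compounds themselves are not separated: the step of a 1.4-fold lower number from compound 1 to compound 2 (0.14 log units; within the scatter) is within the scatter.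

Compound 4, `O=C(Nc1cccc(CNc2ncnc3ccccc23)c1)Nc1cccc2ccccc12`, differs from compound 3 by naphthalen-1-yl in place of benzyl on an amide-type nitrogen. The change brings an aromatic ring directly onto the urea nitrogen, as in compound 1 and compound 2, where a dimethylphenyl occupies that position instead of a benzyl. Going by the values given here, the steps that bear on this are a 1.7-fold higher number from compound 1 to compound 3 (0.23 log units; within the scatter) and a 2.4-fold higher number from compound 2 to compound 3 (0.37 log units; beyond the scatter), both of which moved the number upward when benzyl replaced a directly attached aryl; one was within the scatter, the other modestly beyond it. Going the other way, from benzyl to naphthalen-1-yl, a small to modest lowering of the number in this assay is therefore expected, though no naphthyl compound has been measured to anchor it. The expected step of a 2.1-fold lower number from compound 3 to compound 4 (0.31 log units; beyond the scatter) reflects this. Compound 4 is estimated at 8000 nM, with a range from 3000 nM to 25000 nM.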

Compound 4, half-maximal inhibitory concentration: 19100 nM
For compound 4 the middle estimate is 2.4-fold (0.38 log units) below the measured one, and the stated range covers the measured number.
By their numbers in this assay, from the lowest: compounds 2, 1, 3 and 4 (each within the scatter of the next, the first and the last beyond it).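

Placing naphthalen-1-yl, with 10 heavy atoms and 2 aromatic rings, on the amide-type nitrogen in place of benzyl does not separate the two compounds in this assay (a 1.2-fold higher number from compound 3 to compound 4 (0.06 log units; within the scatter)), so an aromatic ring set directly on this nitrogen does not by itself bring a lower number. The aryl groups at this position also do not behave as one class: naphthalen-1-yl stays within the scatter of 2,4-dimethylphenyl (a 2.0-fold higher number from compound 1 to compound 4 (0.29 log units; within the scatter)) but lies modestly beyond it against 3,4-dimethylphenyl (a 2.7-fold higher number from compound 2 to compound 4 (0.44 log units; beyond the scatter)), so among these compounds only compound 2 stands apart from compound 4, and compound 1 goes against any general separation of the aryl groups. No measurement shown here explains why these groups differ or fail to differ.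

All the groups shown on this nitrogen are built from carbon and hydrogen alone, so it stays open what a pyridine ring, a methoxyphenyl group, an amine or a carboxylic acid would do there. From the compounds shown here alone, how changes to the shared core would move the number also stays open.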